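This account rests on a few compounds, and the source may have more. Where it says the series, first, only, none or still open, it means among the compounds named here.

Measured compounds:
Compound 1 `COc1ccc(C)cc1NC(=O)CSc1nnc(-c2ccoc2C)n1Cc1ccco1` gives 2510 nM in a functional assay on CHO cells for antagonist activity at Orexin/Hypocretin receptor type 1 (Homo sapiens), read by FLIPR and calcium flux; on this read-out lower numbers stand for stronger inhibition and higher numbers for weaker inhibition.
Compound 2 `Cc1ccc(NC(=O)CSc2nnc(-c3ccoc3C)n2Cc2ccco2)cc1` gives no number in this assay but a limit, > 15800 nM.

Within the data shown here, compound 1 therefore holds the only real number in this assay; the other value is a limit (the limit of > 15800 nM in this assay, at which 1 of the 2 values shown sits). Compound 3 `Cc1cccc(NC(=O)CSc2nnc(-c3ccoc3C)n2Cc2ccco2)c1` keeps the shared core of compound 1 and changes a single group: hydrogen in place of methoxy on an aromatic carbon. Among the measured compounds shown here, the one measured step that touches this group is an at least 6.2-fold higher number from compound 1 to compound 2 (0.79 log units; beyond the scatter); it too took the methoxy away, yet at the same time it shifted the methyl to another carbon, so it covers the present change only in part. Its direction was toward weaker inhibition, and its size was at least modest. Because an at least 6.2-fold higher number from compound 1 to compound 2 (0.79 log units; beyond the scatter) went that way, the loss of the methoxy alone is expected to cost potency as well, though it is unclear how much of that step came from the methoxy and how much from the moved methyl. Compound 3 is therefore expected to inhibit less strongly than compound 1, by roughly a 3.2-fold higher number from compound 1 to compound 3 (0.50 log units; beyond the scatter). The estimate for compound 3 is 8000 nM, with a range from 3000 nM to 20000 nM.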

Compound 3, inhibition constant: 2510 nM
Compound 3: middle estimate off by 3.2-fold (0.50 log units), on the high side, and the stated range ends above it.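

With hydrogen in place of methoxy on this aromatic carbon, this assay shows no change at the digits printed from compound 1 to compound 3 (within the scatter) and so the methoxy turns out not to be needed for the inhibition seen with compound 1. The inhibition depends instead on where the methyl sits, as the change from a 4-methylphenyl to a 3-methylphenyl on the amide nitrogen gives an at least 6.2-fold lower number from compound 2 to compound 3 (0.79 log units; beyond the scatter). The earlier loss from compound 1 to compound 2 thus now points to the moved methyl rather than to the missing methoxy. Going by these compounds, compound 2 holds only a limit, so the true size of that gain stays unknown and only its lower bound can be read: the limit of > 15800 nM in this assay, at which 1 of the 3 values shown sits.

On these data alone, it remains open whether the methyl of compound 3 is itself required or whether a plain phenyl group, or a larger group such as ethyl, would serve as well at that carbon. Also open, as far as these compounds go, is how a hydroxyl, an ethoxy or an amine would fare in place of the methoxy, and whether a methoxy added to the 4-methylphenyl of compound 2 would restore inhibition.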